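The compounds below may be only part of what the source reports. "The series", "measured", "known", "first", "only" and "open" are said of these compounds alone.

Compound 3 `Cn1cc(-c2nn(Cc3ccc(C(=O)NC4CC4)cc3)c(=O)c3ccccc23)cn1` gives 48200 nM in a functional assay on LoVo cells (Homo sapiens) for antiproliferative activity, read by MTT assay, with a stated time of 72 h (on this read-out higher numbers stand for weaker inhibition and lower numbers for stronger inhibition), the lowest of the two numbers shown. Compound 2 `Cn1cc(-c2nn(Cc3ccc(C(=O)N4CCCCC4)cc3)c(=O)c3ccccc23)cn1` gives 77100 nM. The step of a 1.6-fold lower number from compound 2 to compound 3 (0.20 log units; within the scatter) stays within the scatter. Compound 1 `Cc1noc(C)c1-c1nn(Cc2ccc(C(=O)NC3CCCC3)cc2)c(=O)c2ccccc12`, which also carries a cyclopentylcarbamoyl group but on a different core, reaches only a limit of the assay, > 100000 nM (the limit of > 100000 nM in this assay, at which 1 of the 3 values shown sits). Compound 4 `Cn1cc(-c2nn(Cc3ccc(C(=O)NC4CCCC4)cc3)c(=O)c3ccccc23)cn1` differs from compound 3 by cyclopentyl in place of cyclopropyl on an amide-type nitrogen. Among the measured compounds shown here, no measured step changes this ring on its own; the one measured step, exchanging a piperidin-1-yl for a cyclopropylamino, was small. The step of a 1.7-fold higher number from compound 3 to compound 4 (0.22 log units; within the scatter) is therefore expected to be modest, if anything toward a higher number. Compound 4 is estimated at 80000 nM, within 30000 nM to 200000 nM.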

Compound 4, half-maximal inhibitory concentration: 23700 nM
Beside the measured number, compound 4's estimate is 3.4-fold (0.53 log units) above it; the whole stated range lies above it.
By their numbers in this assay, from the lowest: compound 4; then compounds 3 and 2 (each within the scatter of the next). At a limit, above all of these: compound 1.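

Cyclopentyl in place of cyclopropyl on the amide-type nitrogen gives a 2.0-fold lower number from compound 3 to compound 4 (0.31 log units; beyond the scatter), so unlike the earlier amide exchange, a change at this nitrogen now clears the scatter. Cyclopentylamino in place of piperidin-1-yl gives a 3.3-fold lower number from compound 2 to compound 4 (0.51 log units; beyond the scatter), a clearer separation on the same carbonyl carbon. With the cyclopentylcarbamoyl group kept, 1-methyl-1H-pyrazol-4-yl in place of 3,5-dimethyl-1,2-oxazol-4-yl gives an at least 4.2-fold lower number from compound 1 to compound 4 (0.62 log units; beyond the scatter); the value of compound 1 is a limit, not a number.

From the compounds shown here alone, whether a cyclohexyl ring or an open chain such as n-butyl on this nitrogen would lower the number further remains open. So does the effect of an amine on the cyclopentyl ring.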